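A 2,6-dimethylphenyl swap on the shared core

This account rests on a few compounds, and the source may have more. Where it says the series, first, only, none or still open, it means among the compounds named here.

Measured in a functional assay on A549 cells (Homo sapiens) for cytotoxicity, read by MTT assay, with a stated time of 48 h; on this read-out higher numbers stand for weaker inhibition and lower numbers for stronger inhibition:
Compound 1 `CC1(C)CCC[C@]2(C)[C@@H](CC[C@@](C)(O)/C=C/c3cncc4ccccc34)[C@](C)(O)CC[C@@H]12`: 45700 nM
Compound 2 `CC1(C)CCC[C@]2(C)[C@@H](CC[C@@](C)(O)/C=C/c3ccc(Cl)nc3)[C@](C)(O)CC[C@@H]12`: 3280 nM

Compound 2 has the lower of the two numbers in this assay. Compound 3 `Cc1cccc(C)c1/C=C/[C@](C)(O)CC[C@@H]1[C@@]2(C)CCCC(C)(C)[C@@H]2CC[C@@]1(C)O` differs from it in one place, with 2,6-dimethylphenyl in place of 6-chloropyridin-3-yl on a double-bonded chain carbon bound to a double-bonded chain carbon. Going by the values given here, only one measured step bears on this change. It falls at the same place and is large: a 14-fold lower number from compound 1 to compound 2 (1.14 log units; beyond the scatter). That single step shows that the group here can move the number far, but it gives no rule, and neither measured compound carries 2,6-dimethylphenyl. With compound 2 at 3280 nM, the lower of the two values, a moderate rise beyond the scatter is expected, though with wide uncertainty. The expected change is a 2.7-fold higher number from compound 2 to compound 3 (0.44 log units; beyond the scatter). The estimate for compound 3 is 9000 nM, within an expected range of 2500 nM to 32000 nM.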

Compound 3, half-maximal inhibitory concentration: 3340 nM
Compound 3: the middle estimate sits 2.7-fold (0.43 log units) above what was measured; measured number inside the range.
By their numbers in this assay, from the lowest: compounds 2 and 3 (each within the scatter of the next); then compound 1.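

In this assay the change gives a 1.0-fold higher number from compound 2 to compound 3 (0.01 log units; within the scatter) and so does not separate 2,6-dimethylphenyl from 6-chloropyridin-3-yl: at this place, an aromatic ring of carbon only, with no hydrogen-bond acceptor, matches a ring with one hetero atom and a chlorine. The step of a 14-fold lower number from compound 1 to compound 3 (1.14 log units; beyond the scatter) shows that the earlier gap was not particular to 6-chloropyridin-3-yl, since among these three groups isoquinolin-4-yl alone stands apart. Nothing available here explains this match or that gap.

The compounds shown leave open whether any group at this place takes the number clearly past the level shared by compound 2 and compound 3. An aromatic ring carrying an amine or a carboxylic acid could stay at that level or leave it.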